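The source may report more compounds than this note shows. Statements on the series, on what has been measured and on what is new or still open speak of the compounds shown alone.

Compound 2 `CN(C(=O)NC(=O)c1ccccc1F)c1nc(C(F)(F)F)c(C(=O)N/N=C/c2cccc(C(F)(F)F)c2)s1` and compound 3 `CN(C(=O)NC(=O)c1ccccc1F)c1nc(C(F)(F)F)c(C(=O)N/N=C/c2ccc(C(F)(F)F)cc2)s1` share a core and differ only in one part: 4-(trifluoromethyl)phenyl in place of 3-(trifluoromethyl)phenyl on a carbon with a double bond to nitrogen. In a functional assay on HeLa cells (Homo sapiens) for inhibition, read by MTT assay, with a stated time of 72 h (on this read-out higher numbers stand for weaker inhibition and lower numbers for stronger inhibition), compound 2 gives 19.1 ug/mL, while compound 3 gives 3.97 ug/mL, a step of a 4.8-fold lower number from compound 2 to compound 3 (0.68 log units; beyond the scatter). Compound 1 `CNc1nc(C(F)(F)F)c(C(=O)N/N=C/c2cccc(C(F)(F)F)c2)s1` is made from compound 2 by a different change, (hydrogen in place of ((2-fluorophenyl)carbonyl)carbamoyl on a nitrogen on an aromatic ring). For compound 1 this assay reports only a limit, > 100 ug/mL. That change therefore gave an at least 5.2-fold higher number from compound 2 to compound 1 (0.71 log units; beyond the scatter), a weakening whose full size is hidden because the value sits at the limit of > 100 ug/mL in this assay, at which 1 of the 3 values shown sits. Compound 4 `CNc1nc(C(F)(F)F)c(C(=O)N/N=C/c2ccc(C(F)(F)F)cc2)s1` carries the same change as applied to compound 3: hydrogen in place of ((2-fluorophenyl)carbonyl)carbamoyl on a nitrogen on an aromatic ring. Since compound 3 starts from a lower number than compound 2, the same loss is expected to leave compound 4 below the limit more often, and the step of a 10-fold higher number from compound 3 to compound 4 (1.00 log units; beyond the scatter) is estimated to be similar to that earlier one. Compound 4 is therefore expected to give about 40 ug/mL, within 10 ug/mL to 150 ug/mL.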

Compound 4, half-maximal inhibitory concentration: > 100 ug/mL
Compound 4: only a limit was reported; the forecaster's own chance of this, stated with the estimate: 30%; at least 2.5-fold (0.39 log units) between middle value and limit.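

In this assay, compound 4 gives > 100 ug/mL, which is a limit of the assay and not a number. Replacing ((2-fluorophenyl)carbonyl)carbamoyl with hydrogen on the nitrogen gave an at least 25-fold higher number from compound 3 to compound 4 (1.40 log units; beyond the scatter), so on both cores shown the change moves the number in the same direction, towards weaker inhibition: the same change on two cores in this assay, an at least 5.2-fold higher number (0.71 log units; beyond the scatter) from compound 2 to compound 1 and an at least 25-fold higher number (1.40 log units; beyond the scatter) from compound 3 to compound 4; the limit leaves it open whether they differ. As far as these compounds go, the direction therefore carries from one core to the other, but the true size of either step stays unknown, and the two sizes cannot be compared: the limit of > 100 ug/mL in this assay, at which 2 of the 4 values shown sit.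

The compounds shown leave open how much of the group is needed. A smaller group on that nitrogen, such as an acetyl or a plain carbamoyl, might or might not keep the lower numbers of compound 2 and compound 3.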